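This account rests on a few compounds, and the source may have more. Where it says the series, first, only, none or still open, it means among the compounds named here.

Compound 1 `C[Se]c1nc(NCc2ccccc2)c2ccccc2n1` and compound 2 `CSc1nc(NCc2ccccc2)c2ccccc2n1` share one core, and compound 3 `CSc1ccc(CNc2nc(SC)nc3ccccc23)cc1` carries the core of compound 2 with a further group. In a functional assay on HTB-54 cells (Homo sapiens) for cytotoxicity, read by MTT assay, with a stated time of 72 h (a lower number here means a stronger inhibitor of growth, a higher number a weaker inhibitor of growth), compound 2 gives 37900 nM, while compound 1 gives 74600 nM and compound 3 gives 7220 nM. Compound 1 differs from compound 2 by a group of 2 heavy atoms (1 carbon, 1 selenium; no ring) in place of a group of 2 heavy atoms (1 carbon, 1 sulfur; no ring), on an aromatic carbon, and this change made a 2.0-fold higher number from compound 2 to compound 1 (0.29 log units; within the scatter). Compound 3 differs from compound 2 by methylsulfanyl in place of hydrogen on an aromatic carbon, and this change made a 5.2-fold lower number from compound 2 to compound 3 (0.72 log units; beyond the scatter). Compound 4 `CSc1ccc(CNc2nc([Se]C)nc3ccccc23)cc1` has not yet been measured; it differs from compound 3 by a group of 2 heavy atoms (1 carbon, 1 selenium; no ring) in place of a group of 2 heavy atoms (1 carbon, 1 sulfur; no ring), on an aromatic carbon. Going by the values given here, this is the same kind of change as the one from compound 2 to compound 1, though not on the same compound: in compound 3 the place is meta to a large group. The step from compound 3 to compound 4 in this assay is expected to be a 1.7-fold higher number from compound 3 to compound 4 (0.22 log units; within the scatter), placed beside the earlier step, because the earlier change gave a 2.0-fold higher number from compound 2 to compound 1 (0.29 log units; within the scatter) and compound 3 starts from 7220 nM. Compound 4 is therefore estimated at 12000 nM, with a range from 5000 nM to 30000 nM.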

Compound 4, concentration for 50% growth inhibition: 37900 nM
Beside the measured number, compound 4's estimate is 3.2-fold (0.50 log units) below it, and the stated range ends below it.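

In this assay, putting the selenium-bearing group in place of methylsulfanyl on the aromatic carbon between two ring nitrogen atoms gave a 5.2-fold higher number from compound 3 to compound 4 (0.72 log units; beyond the scatter), and this step does not match its counterpart on the other core: the same change on two cores in this assay, a 2.0-fold higher number (0.29 log units; within the scatter) from compound 2 to compound 1 and a 5.2-fold higher number (0.72 log units; beyond the scatter) from compound 3 to compound 4, 2.7-fold (0.43 log units) apart, beyond the scatter of two such steps. Seen from the other side of the same set of compounds, methylsulfanyl in place of hydrogen gave a 2.0-fold lower number from compound 1 to compound 4 (0.29 log units; within the scatter), which also differs from the earlier step: the same change on two cores in this assay, a 5.2-fold lower number (0.72 log units; beyond the scatter) from compound 2 to compound 3 and a 2.0-fold lower number (0.29 log units; within the scatter) from compound 1 to compound 4, 2.7-fold (0.43 log units) apart, beyond the scatter of two such steps. Each change moved the number in the same direction on both cores, but its size did not carry over, so the two changes are not independent in these four compounds, and these data do not show what lies behind that or whether it extends to other compounds in the series.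

The compounds shown leave open whether a longer chain or an amine at the place between two ring nitrogen atoms would follow the same pattern. They also leave open how a methoxy group or a chlorine atom would behave in place of the added methylsulfanyl.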